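Cyclohexyl in place of methylthiophene on a beta-lactam scaffold

A few compounds are considered here, and "the series" means these few. Any claim that something is new, unique, unknown or untested is made for them only; others in the source may bear on it.

Measured compounds:
compound 1 `COc1ccc([C@@H]2C(c3ccc(C)s3)C(=O)N2c2cc(OC)c(OC)c(OC)c2)cc1`: 250 nM
compound 2 `COc1ccc([C@@H]2[C@@H](C(=O)c3ccsc3)C(=O)N2c2cc(OC)c(OC)c(OC)c2)cc1`: 470 nM
compound 3 `COc1cc(N2C(=O)[C@H](c3cccs3)[C@H]2c2cccc3ccccc23)cc(OC)c1OC`: 620 nM

In a functional assay on MCF7 cells (Homo sapiens) for antiproliferative activity, read by MTT assay (a higher number here means a weaker inhibitor, a lower number a stronger inhibitor), compound 1 gives 250 nM, the lowest of the three numbers, although compound 2 lies within the usual scatter of it, so the two cannot be separated; only compound 3 sits beyond the scatter. Compound 4 `COc1ccc([C@@H]2C(C3CCCCC3)C(=O)N2c2cc(OC)c(OC)c(OC)c2)cc1` is a single change from compound 1: cyclohexyl in place of 5-methylthiophen-2-yl on a saturated ring carbon. Among the measured compounds shown here, no pair of measured compounds shows this kind of change, so there is no measured step to lean on. Replacing the aromatic ring with a saturated one is expected to cost some potency in this assay, a step from compound 1 to compound 4 of a 2.4-fold higher number from compound 1 to compound 4 (0.38 log units; beyond the scatter). Compound 4 is therefore estimated at 600 nM, within a range of 200 nM to 2000 nM.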

Compound 4, half-maximal inhibitory concentration: 580 nM
Beside the measured number, compound 4's estimate is 1.0-fold (0.01 log units) above it, within the range that was stated.
By their numbers in this assay, from the lowest: compounds 1, 2, 4 and 3 (each within the scatter of the next, the first and the last beyond it).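

Swapping 5-methylthiophen-2-yl for cyclohexyl on this saturated ring carbon gives, in this assay, a 2.3-fold higher number from compound 1 to compound 4 (0.37 log units; beyond the scatter), a modest step. This position therefore accepts a non-aromatic ring of carbon only and keeps activity, at a measurable but limited cost. Nothing available explains the size of this step. The compounds shown leave open whether the step follows from losing the aromatic ring or from losing the sulfur, which a phenyl group here could help separate. Going by these compounds, how an open chain such as n-butyl, or an amine, would fare at this position also remains unknown.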